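This account rests on a few compounds, and the source may have more. Where it says the series, first, only, none or still open, it means among the compounds named here.

Compound 1, `O=C1NC(c2ccccc2)CN1S(=O)(=O)c1ccc2c(c1)CCCN2`, carries a hydrogen on the nitrogen of the non-aromatic ring of the shared core. In a functional assay on A549 cells (Homo sapiens) for antiproliferative activity, read by MTT assay (on this read-out higher numbers stand for weaker inhibition and lower numbers for stronger inhibition), compound 1 gives only a limit, > 20000 nM. Compound 1 therefore stands at the limit of > 20000 nM in this assay, at which 2 of the 3 values shown sit. Compound 2, `CCCOC(=O)N1CCCc2cc(S(=O)(=O)N3CC(c4ccccc4)NC3=O)ccc21`, gives 1030 nM in this assay. Compound 3, `O=C(OCCCl)N1CCCc2cc(S(=O)(=O)N3CC(c4ccccc4)NC3=O)ccc21`, gives only a limit in this assay, > 20000 nM. The measured steps: an at least 19-fold lower number from compound 1 to compound 2 (1.28 log units; beyond the scatter); a step that the two limits leave unreadable from compound 1 to compound 3; an at least 19-fold higher number from compound 2 to compound 3 (1.28 log units; beyond the scatter).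

Compound 4, `O=C1NC(c2ccccc2)CN1S(=O)(=O)c1ccc2c(c1)CCCN2C(=O)C(F)(F)F`, is still to be measured in this assay. It differs from compound 1 as follows: (trifluoromethyl)carbonyl in place of hydrogen on a nitrogen on an aromatic ring in a ring. For the measured compounds named here, the one readable step at this position is an at least 19-fold lower number from compound 1 to compound 2 (1.28 log units; beyond the scatter), a large gain with a carbamate; the step that the two limits leave unreadable from compound 1 to compound 3, however, shows that a different acyl group here need not bring a readable gain. The entering group is a carbonyl-bearing substituent but not a carbamate, so a smaller step than with compound 2 is expected: an at least 2.8-fold lower number from compound 1 to compound 4 (0.45 log units; beyond the scatter). For compound 4 the estimate is 7000 nM, with a range from 1500 nM to 20000 nM.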

Compound 4, half-maximal inhibitory concentration: > 20000 nM
Compound 4 was reported as a limit; the forecaster's own chance of this, stated with the estimate: 40%; middle value at least 2.8-fold (0.45 log units) away from the limit.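

In this assay compound 4 gives only a limit, > 20000 nM, and this is a limit rather than a number. With trifluoromethyl in place of propoxy on the carbonyl carbon, the step is an at least 19-fold higher number from compound 2 to compound 4 (1.28 log units; beyond the scatter), so a carbonyl group on this nitrogen does not by itself give a readable value: of the three acyl groups shown here, only propoxycarbonyl gives a number. The steps from compound 1 to compound 4 and from compound 3 to compound 4 cannot be read, and the series gathers at one end of the scale: the limit of > 20000 nM in this assay, at which 3 of the 4 values shown sit.

From the compounds shown here alone, it remains open whether the gain belongs to the carbamate as such or to its propyl chain; ethoxycarbonyl and butoxycarbonyl groups on this nitrogen would separate the two. Also open, going by these compounds, is how a plain acetyl group would compare with the trifluoroacetyl-type (trifluoromethyl)carbonyl group.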